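Cyanoguanidine series: isopropyl in place of phenethyl

A few compounds are considered here, and "the series" means these few. Any claim that something is new, unique, unknown or untested is made for them only; others in the source may bear on it.

Measured so far:
compound 1 `N#C/N=C(\NCCCc1ccccc1)NCCCc1c[nH]cn1` 5.25
compound 2 `N#C/N=C(/NCCCCc1c[nH]cn1)NCCCc1ccccc1` 5.25

Within the data shown here, in an in vitro functional assay on Sf9 cells for antagonist activity at histamine H2 receptor (Homo sapiens) (a lower number here means a less potent compound, a higher number a more potent compound, by a factor of ten per unit of this negative logarithm), compound 2 gives 5.25, level with compound 1 at 5.25; the only measured step, no change at the digits printed from compound 1 to compound 2 (within the scatter), lies within the scatter. Compound 3 `CC(C)CN/C(=N\C#N)NCCCCc1c[nH]cn1` differs from compound 2 by isopropyl in place of phenethyl on a saturated chain carbon bound to an amine nitrogen. Among the measured compounds shown here, no measured step touches the group on the saturated chain carbon bound to an amine nitrogen, so there is no direct guide. The expectation for compound 3 is a small step, a number 0.15 log units lower from compound 2 to compound 3 (within the scatter), not clearly beyond the scatter. Compound 3 is expected at 5.1, with a range from 4.5 to 5.8.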

Compound 3, negative logarithm of the antagonist equilibrium constant: < 5
Compound 3: a limit, no number; the forecaster's own chance of this, stated with the estimate: 10%; middle value at least 0.10 log units from the limit.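

In this assay, among these compounds, isopropyl in place of phenethyl gives the first reading for a change on a saturated chain carbon bound to an amine nitrogen: a number at least 0.25 log units lower from compound 2 to compound 3 (that floor lies within the scatter). Compound 3 gives < 5, which is a limit and not a number. The step is therefore only a floor, so a real loss on leaving phenethyl is neither established nor excluded, and its size cannot be read: the limit of < 5 in this assay, at which 1 of the 3 values shown sits.

Open, from the compounds shown here alone, is what a benzyl or a cyclohexyl group would give at this place. Also open, going by these compounds, is whether an amine at the end of that chain would change the reading.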